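Swapping chloro for amino: a small step expected

The source may report more compounds than this note shows. Statements on the series, on what has been measured and on what is new or still open speak of the compounds shown alone.

Compound 3 `ClCc1ccc(Cn2cnc3c(Cl)nc(Cl)nc32)cc1` and compound 1 `Nc1nc(Cl)c2ncn(Cc3ccc(CCl)cc3)c2n1` share a core and differ in one place. In a functional assay on COLO 205 cells (Homo sapiens) for cytotoxicity, read by sulforhodamine B assay, with a stated time of 48 h (on this read-out higher numbers stand for weaker inhibition of growth and lower numbers for stronger inhibition of growth), compound 3 gives 3470 nM, and compound 1 gives 3630 nM. The change between them, (amino in place of chloro on an aromatic carbon), produced a 1.0-fold higher number from compound 3 to compound 1 (0.02 log units; within the scatter). Compound 2 `ClCc1cccc(Cn2cnc3c(Cl)nc(Cl)nc32)c1` is built from the same atoms as compound 3, joined differently; the difference between the two cores is not broken down here. In this assay compound 2 gives 2230 nM. Compound 4 `Nc1nc(Cl)c2ncn(Cc3cccc(CCl)c3)c2n1` arises from compound 2 by the same change, (amino in place of chloro on an aromatic carbon), at a place described in identical words. Since that change gave only a 1.0-fold higher number from compound 3 to compound 1 (0.02 log units; within the scatter), a similarly small step is expected here: a 1.0-fold higher number from compound 2 to compound 4 (0.01 log units; within the scatter). Compound 4 is therefore estimated at 2300 nM, expected to lie between 1200 nM and 4500 nM.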

Compound 4, concentration for 50% growth inhibition: 6760 nM
Compound 4: the middle estimate sits 2.9-fold (0.47 log units) below what was measured; measured number above the stated range.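

In this assay, putting amino in place of chloro on an aromatic carbon gave a 3.0-fold higher number from compound 2 to compound 4 (0.48 log units; beyond the scatter), so growth inhibition became weaker on this core. The same change therefore did not carry over at the same size from one core to the other: the same change on two cores in this assay, a 1.0-fold higher number (0.02 log units; within the scatter) from compound 3 to compound 1 and a 3.0-fold higher number (0.48 log units; beyond the scatter) from compound 2 to compound 4, 2.9-fold (0.46 log units) apart, beyond the scatter of two such steps. This shows that, for these two pairs, a step measured on one core was a poor guide to the step on the other, but two pairs cannot show why the steps differ or which size is more typical of the series.

The compounds shown leave open how a methylamino or methoxy group would behave at this aromatic carbon. They also leave open whether either group would give steps that differ between these two cores.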